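Cyano for iodo on the core of compound 1

This account rests on a few compounds, and the source may have more. Where it says the series, first, only, none or still open, it means among the compounds named here.

Compound 1 `Ic1ccc(-n2ccc3ccncc32)cc1` stands lowest of the two values in hand: in an assay on isolated protein for inhibition of Aromatase (Homo sapiens), read by fluorescence, tested at 1 uM (a lower number here means less inhibition, a higher number more inhibition at the concentration tested (going by the name of the read-out)), compound 1 gives 26%, whereas compound 2 `N#Cc1ccc(Oc2cccnc2)cc1Oc1cccnc1`, a separate structure carrying a nitrile, gives 81%, a gap beyond the scatter. Compound 3 `N#Cc1ccc(-n2ccc3ccncc32)cc1` differs from compound 1 by cyano in place of iodo on an aromatic carbon. Among the compounds with values here, no step between two measured compounds matches this change, so the expectation leans on the nitrile-bearing compound 2 and its 81%. A rise in this assay is expected, the step estimated as a number 34 percentage points higher from compound 1 to compound 3 (beyond the scatter). Compound 3 is accordingly expected near 60%, between 30% and 88%.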

Compound 3, a percentage reported as inhibition, at one concentration (the size of the read-out at that concentration, not a potency): 94%
For compound 3 the middle estimate is 34 percentage points below the measured one; the measured number lies above the stated range.
By their numbers in this assay, from the lowest: compound 1; then compound 2; then compound 3.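

On the core of compound 1, the aromatic carbon para to a group of 9 heavy atoms responds strongly to its substituent: in this assay, cyano in place of iodo gives a number 68 percentage points higher from compound 1 to compound 3 (beyond the scatter). Within the data shown here, this is the first step read at this position, with everything else in the structure held constant. No measurement in hand accounts for its size.

Among the compounds shown, this carbon carries only iodo or cyano, so it stays open how an amine, a carboxylic acid or a chloro group would compare with compound 3 at 94%. As far as these compounds go, whether the step carries over to another core also stays open.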